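From a long side group to a small cyclopropyl

The source may report more compounds than this note shows. Statements on the series, on what has been measured and on what is new or still open speak of the compounds shown alone.

Compound 1 `CCCCc1nc(=O)c(S(=O)(=O)c2ccc(-c3ccnc(NC(=O)C4CC4)c3)cc2)c(O)n1-c1c(OC)cccc1OC` gives 72%
Compound 2 `CCCCc1[nH]c(=O)c(S(=O)(=O)c2ccc(-c3ccncc3C)cc2)c(O)c1-c1c(OC)cccc1OC` gives 57%

Both numbers come from an ADME assay on microsomes from liver (Rattus norvegicus) for metabolic stability, using NADPH, with a stated time of 10 min (on this read-out lower numbers stand for a less stable compound and higher numbers for a more stable compound), and compound 1 stands highest of the two, with compound 2 lower by more than the usual scatter. Compound 3 `CCCCc1nc(=O)c(S(=O)(=O)c2ccc(C3CC3)cc2)c(O)n1-c1c(OC)cccc1OC` has not been measured yet. It carries cyclopropyl in place of 2-((cyclopropylcarbonyl)amino)pyridin-4-yl on an aromatic carbon and otherwise matches compound 1. Within the data shown here, no measured pair shows this swap, so the expectation is uncertain. In this assay no step beyond the scatter is expected, and the estimate of a number 7 percentage points lower from compound 1 to compound 3 (within the scatter) stays within it. For compound 3 the estimated value is 65% with a range from 42% to 85% as expected here.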

Compound 3, percent of the compound remaining: 59%
The estimate for compound 3 lay 6 percentage points above the measured number, within the range that was stated.
By their numbers in this assay, from the lowest: compounds 2 and 3 (each within the scatter of the next); then compound 1.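

In this assay, putting cyclopropyl in place of 2-((cyclopropylcarbonyl)amino)pyridin-4-yl gives a number 13 percentage points lower from compound 1 to compound 3 (beyond the scatter), the first step measured at this position. On this aromatic carbon, the read-out therefore responds to the group attached, and in this pair the larger group goes with the more stable compound. Nothing given here explains the step.

Going by these compounds, how an amine or a longer chain would read on this aromatic carbon remains open. So does whether the difference follows the six-membered aromatic ring of the departing group or its cyclopropylcarbonyl part.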